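Butoxyphenyl series: tolerance on A549 cells, cyclopropylmethyl to naphthylmethyl

The compounds below may be only part of what the source reports. "The series", "measured", "known", "first", "only" and "open" are said of these compounds alone.

Compound 1 `CCCCOc1ccc(-c2nc3ncccn3c2NCC2CC2)cc1` carries a cyclopropylmethyl group on the ring nitrogen. In a toxicity assay on A549 cells (Homo sapiens) for cytotoxicity, read by luminescence and CellTiter-Glo, with a stated time of 48 h (a higher number here means that more compound is tolerated, a lower number that less compound is tolerated), compound 1 gives only a limit, > 100000 nM, not a number. Compound 2 `CCCCOc1ccc(-c2nc3ncccn3c2N)cc1` has hydrogen in place of cyclopropylmethyl on a nitrogen on an aromatic ring. In this assay compound 2 likewise gives only a limit, > 100000 nM. The step that the two limits leave unreadable from compound 1 to compound 2 cannot be read, since the limit of > 100000 nM in this assay, at which 2 of the 2 values shown sit, holds both values. Compound 1 therefore stands only at a limit, with no measured neighbour that fixes a number.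

Compound 3 `CCCCOc1ccc(-c2nc3ncccn3c2NCc2ccc3ccccc3c2)cc1` differs from compound 1 by naphthalen-2-yl in place of cyclopropyl on a saturated chain carbon bound to a nitrogen on an aromatic ring. Within the data shown here, no measured step bears on this change; the one step measured is unreadable. The expectation rests on compound 1 alone, whose value > 100000 nM is a limit, so any readable number for compound 3 would appear as a drop in tolerance, and the estimated step of an at least 1.4-fold lower number from compound 1 to compound 3 (0.15 log units; that floor lies within the scatter) is accordingly set toward less tolerated. Compound 3 is expected at 70000 nM, with a range from 20000 nM to 200000 nM, and a fair chance that this assay again reports only a limit.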

Compound 3, half-maximal cytotoxic concentration: 33000 nM
The estimate for compound 3 lay 2.1-fold (0.33 log units) above the measured number, and the stated range covers the measured number.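

The series now holds a readable number in this assay: on a saturated chain carbon bound to a nitrogen on an aromatic ring, naphthalen-2-yl in place of cyclopropyl gives an at least 3.0-fold lower number from compound 1 to compound 3 (0.48 log units; beyond the scatter). This step lies beyond the scatter, so a change at this position can bring the read-out off the limit, which the earlier pair could not show, its step being unreadable. The true size of the new step remains open, and only its floor can be stated, since one end of it is a limit: the limit of > 100000 nM in this assay, at which 2 of the 3 values shown sit.

Going by these compounds, a single pair cannot separate the effect of the larger count of carbon atoms from that of the two six-membered aromatic rings, and it remains open whether phenyl, a longer alkyl chain such as n-hexyl, or a group with heteroatoms such as pyridin-3-yl in the same place would also give a readable number. On these data alone, it is equally open how far the number would move with a carboxylic acid or an amine on naphthalen-2-yl, or with a shorter chain in place of the butoxy group on the shared core.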